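This account rests on a few compounds, and the source may have more. Where it says the series, first, only, none or still open, it means among the compounds named here.

Compound 2 `CO[C@@H]1CC=C2N(c3ccc4[nH]ccc4c3)C(=O)C[C@]2(c2ccccc2)O1` gives 5100 nM in a functional assay on A549 cells (Homo sapiens) for cytotoxicity, read by sulforhodamine B assay, with a stated time of 48 h (on this read-out higher numbers stand for weaker inhibition and lower numbers for stronger inhibition), and so holds the lowest of the two numbers recorded. Its nearest neighbour is compound 1 `CO[C@@H]1CC=C2N(c3ccc([N+](=O)[O-])cc3)C(=O)C[C@]2(c2ccccc2)O1`, which in this assay gives 7150 nM. Going by the values given here, the only step measured between these two, a 1.4-fold lower number from compound 1 to compound 2 (0.15 log units; within the scatter), swapped one aromatic group for another on the amide-type nitrogen in the ring and stayed within the scatter. Compound 3 `CO[C@@H]1CC=C2N(c3c[nH]c4ccccc34)C(=O)C[C@]2(c2ccccc2)O1` carries the change (1H-indol-3-yl in place of 1H-indol-5-yl on an amide-type nitrogen in a ring); the same atoms are present, joined differently, so the indole is attached through its five-membered ring instead of its six-membered ring. With a single relevant step that itself did not leave the scatter, there is no basis for expecting a shift beyond the scatter in this assay in either direction. Compound 3 is therefore estimated at 5000 nM, with a range of 2000 nM to 13000 nM, which is expected to amount to a 1.0-fold lower number from compound 2 to compound 3 (0.01 log units; within the scatter).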

Compound 3, half-maximal inhibitory concentration: 5200 nM
Estimate against measurement, compound 3: 1.0-fold (0.02 log units) below; the measured number falls inside the stated range.
By their numbers in this assay, from the lowest: compounds 2, 3 and 1 (each within the scatter of the next).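

Replacing 1H-indol-5-yl with 1H-indol-3-yl on the amide-type nitrogen in the ring gives a 1.0-fold higher number from compound 2 to compound 3 (0.01 log units; within the scatter) in this assay and shows that, for these two compounds, the point of attachment of the indole does not move the number beyond the scatter. The comparison with the 4-nitrophenyl group gives a 1.4-fold lower number from compound 1 to compound 3 (0.14 log units; within the scatter) and adds a second indole attachment that stays within the scatter of that group, so all three aromatic groups shown on this nitrogen lie within the scatter of one another. No evidence is available to explain why these numbers stay so close.

Going by these compounds, it remains open how a group of another kind on this nitrogen, such as a carboxylic acid, an aminoalkyl chain or a plain methyl group, would read in this assay. On these data alone, the phenyl and methoxy groups are the same in all three compounds, so their contribution also remains open.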